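The source may report more compounds than this note shows. Statements on the series, on what has been measured and on what is new or still open speak of the compounds shown alone.

Measured compounds in a functional assay on the whole organism for positive allosteric modulation, with Mus musculus as the target; a lower number here means that less compound is needed, a higher number that more compound is needed for the effect:

compound 1 `CCC(=O)N(c1cccc(Br)c1)C1CCCC1N(C)C`: 0.1 mg/kg
compound 2 `CCC(=O)N(c1ccc(Br)cc1)C1CCCC1N(C)C`: 2 mg/kg
compound 3 `CCC(=O)N(c1cccc(C(F)(F)F)c1)C1CCCC1N(C)C`: 0.3 mg/kg

Compound 2 gives the highest number of the three in this assay; compound 3 stands nearest to it and compound 1 furthest, both gaps beyond the scatter. The difference between the core of compound 1 and the core of compound 2 is not broken down here; the two are built from the same atoms, joined differently.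

One single-point change has been measured so far: trifluoromethyl in place of bromo on an aromatic carbon. It gave a 3.0-fold higher number from compound 1 to compound 3 (0.48 log units; beyond the scatter).

Compound 4 `CCC(=O)N(c1ccc(C(F)(F)F)cc1)C1CCCC1N(C)C` is not yet measured. Its difference from compound 2 is trifluoromethyl in place of bromo on an aromatic carbon. Among the measured compounds shown here, this is the same kind of change as the one from compound 1 to compound 3, but not the same change: in compound 3 the trifluoromethyl sits meta to a large group, in compound 4 para to a large group. For the measured compounds named here, only the one measured example is available as a guide, and whether its size carries over from one place to the other cannot be read from three compounds, so the expected range is kept wide.

For compound 4 the expected step is a 3.0-fold higher number from compound 2 to compound 4 (0.48 log units; beyond the scatter), resting on a 3.0-fold higher number from compound 1 to compound 3 (0.48 log units; beyond the scatter). Compound 4 is therefore expected to give 6 mg/kg in this assay, with the estimate spanning 2 mg/kg to 20 mg/kg.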

Compound 4, dose for half-maximal effect: 10 mg/kg
Beside the measured number, compound 4's estimate is 1.7-fold (0.22 log units) below it; the range from low to high includes it.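

In this assay, trifluoromethyl in place of bromo, para to a large group, gave a 5.0-fold higher number from compound 2 to compound 4 (0.70 log units; beyond the scatter). Set beside the earlier example, this step points the same way, and its size cannot be told apart from that of the first, so across these two pairs the change carries over from one core to the other: the same change on two cores in this assay, a 3.0-fold higher number (0.48 log units; beyond the scatter) from compound 1 to compound 3 and a 5.0-fold higher number (0.70 log units; beyond the scatter) from compound 2 to compound 4, 1.7-fold (0.22 log units) apart, within the scatter of two such steps. This rests on two pairs only, both with the same amide and amine parts, so it does not establish a rule for other cores in the series, and a dose read-out from the whole organism does not show what lies behind either step.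

The compounds shown leave open whether other replacements for bromo, such as chloro, methoxy or a nitrile, would follow the same direction in this assay. They also leave open whether the step would hold with a longer chain on the carbonyl, or with a secondary amine or a cyclic amine in place of the dimethylamino group on the shared core.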